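A second 7-chloroquinolin-4-yl group on the ring nitrogen

The compounds below may be only part of what the source reports. "The series", "measured", "known", "first", "only" and "open" are said of these compounds alone.

Compound 2 `CN(CCNCc1cn(-c2cccc(Cl)c2)nn1)CCNc1ccnc2cc(Cl)ccc12` stands level with compound 1 `CN(CCNCc1cn(-c2ccc(F)cc2)nn1)CCNc1ccnc2cc(Cl)ccc12` at the high end of the three numbers: in a functional assay on BXPC-3 cells (Homo sapiens) for antiproliferative activity, read by sulforhodamine B assay, with a stated time of 72 h (on this read-out higher numbers stand for weaker inhibition and lower numbers for stronger inhibition), compound 2 gives 12000 nM, compound 1 gives 12000 nM, and compound 3 `CN(CCNCc1cn(-c2ccc(Br)cc2)nn1)CCNc1ccnc2cc(Cl)ccc12` gives 7900 nM. The measured steps are all small: no change at the digits printed from compound 1 to compound 2 (within the scatter), a 1.5-fold lower number from compound 1 to compound 3 (0.18 log units; within the scatter) and a 1.5-fold lower number from compound 2 to compound 3 (0.18 log units; within the scatter), each within the scatter. Compound 4 `CN(CCNCc1cn(-c2ccnc3cc(Cl)ccc23)nn1)CCNc1ccnc2cc(Cl)ccc12` differs from compound 2 in one place: 7-chloroquinolin-4-yl in place of 3-chlorophenyl on an aromatic nitrogen. Going by the values given here, none of the measured steps replaces the halogenated phenyl on that aromatic nitrogen with anything else, so the precedent is thin, and the expectation is a 1.3-fold lower number from compound 2 to compound 4 (0.12 log units; within the scatter). Compound 4 is therefore estimated at 9000 nM, with a range from 3000 nM to 25000 nM.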

Compound 4, half-maximal inhibitory concentration: 8800 nM
Beside the measured number, compound 4's estimate is 1.0-fold (0.01 log units) above it; measured number inside the range.
By their numbers in this assay, from the lowest: compounds 3, 4, 1 and 2 (each within the scatter of the next).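

On the aromatic nitrogen, 7-chloroquinolin-4-yl, with 11 heavy atoms and a hydrogen-bond acceptor that 3-chlorophenyl lacks, leaves this assay within the scatter of all three halogenated phenyl compounds: a 1.4-fold lower number from compound 2 to compound 4 (0.13 log units; within the scatter) and a 1.4-fold lower number from compound 1 to compound 4 (0.13 log units; within the scatter) and a 1.1-fold higher number from compound 3 to compound 4 (0.05 log units; within the scatter). The position therefore accepts more than a single substituted phenyl without a readable change in this read-out. No measurement at hand accounts for this flat result.

Still open, going by these compounds, is whether a non-aromatic group on that aromatic nitrogen, such as cyclohexyl or a chain ending in an amine or a carboxylic acid, would move the number beyond the scatter.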